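Trading a fluorinated benzothiazole for a hydrazine-linked one

A few compounds are considered here, and "the series" means these few. Any claim that something is new, unique, unknown or untested is made for them only; others in the source may bear on it.

Two close relatives of a flavone-type core have been tested so far. Compound 1 `O=c1cc(-c2ccccc2)oc2cc(OCCCCNc3nc4ccccc4s3)cc(O)c12` carries a four-carbon chain ending in an amine bound to a benzothiazole; in a functional assay on SK-OV-3 cells (Homo sapiens) for cytotoxicity, read by sulforhodamine B assay, with a stated time of 48 h (a higher number here means a weaker inhibitor, a lower number a stronger inhibitor), compound 1 gives 48.5 ug/mL. Compound 2 `O=c1cc(-c2ccccc2)oc2cc(OCCCCNc3nc4ccc(F)cc4s3)cc(O)c12` differs only by a fluoro on the benzothiazole ring, and in this assay compound 2 gives 33.7 ug/mL. The step of a 1.4-fold lower number from compound 1 to compound 2 (0.16 log units; within the scatter) is therefore small, and compound 2 stands at the lower of the two numbers without being separable from compound 1.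

Compound 3 `O=c1cc(-c2ccccc2)oc2cc(OCCCCNNc3nc4ccccc4s3)cc(O)c12` is the next step from compound 2. The change is (1,3-benzothiazol-2-yl)amino in place of 6-fluoro-1,3-benzothiazol-2-yl on an amine nitrogen. Put differently, the same difference cut one bond further out reads (6-fluoro-1,3-benzothiazol-2-yl)amino to ((1,3-benzothiazol-2-yl)amino)amino, so the fluoro goes and an added nitrogen links the chain to the ring.

Among the measured compounds shown here, only the step of a 1.4-fold lower number from compound 1 to compound 2 (0.16 log units; within the scatter) bears on this, and it covers just the fluoro part; nothing measured speaks to the extra nitrogen. The expected step of a 1.3-fold higher number from compound 2 to compound 3 (0.13 log units; within the scatter) is thus a small drift back toward compound 1, with wide uncertainty. Compound 3 is estimated at 45 ug/mL in this assay, ranging from 18 ug/mL to 110 ug/mL.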

Compound 3, half-maximal inhibitory concentration: 51.7 ug/mL
Compound 3: middle estimate off by 1.1-fold (0.06 log units), on the low side; measured number inside the range.
By their numbers in this assay, from the lowest: compounds 2, 1 and 3 (each within the scatter of the next).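

The cleanest reading of the added nitrogen comes from the pair without fluoro. The step (a 1.1-fold higher number from compound 1 to compound 3 (0.03 log units; within the scatter)) changes only that one atom of the link between the chain and the benzothiazole; in this assay this step stays within the scatter, so this insertion on the amine nitrogen produces no measurable difference. The step that removes the fluoro and adds the nitrogen together (a 1.5-fold higher number from compound 2 to compound 3 (0.19 log units; within the scatter)) also stays within the scatter, which means that the two changes made at once do not separate these compounds either. No measurement shown explains why these numbers stay so close together.

On these data alone, all three compounds therefore sit within the scatter of one another, and it remains open whether any change in this part of the molecule can move the number by more than that. A 6-fluoro-1,3-benzothiazol-2-yl group on the added nitrogen would test the two changes in combination, while an oxygen in place of that nitrogen or a longer chain would probe the link itself.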